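The source may report more compounds than this note shows. Statements on the series, on what has been measured and on what is new or still open speak of the compounds shown alone.

Working notes on the series. Two compounds carry numbers in an in vitro ADME assay on microsomes from liver (Mus musculus) for metabolic stability, read by LC-MS, using NADPH, tested at 1 uM, in the presence of a further agent that is not named here (a lower number here means that the compound disappears faster, a higher number that the compound lasts longer), so far. Compound 1 `COc1ccc(C(=O)/C=C/c2ccc(O)c(CN3CCN(c4ccnc5cc(Cl)ccc45)CC3)c2)c(OC)c1` gives 0.757 h in this assay. Compound 2 `COc1cc(/C=C/C(C)=O)ccc1OCc1cn(-c2ccnc3cc(Cl)ccc23)nn1` gives 0.103 h, the lower of the two numbers, the gap to compound 1 lying beyond the scatter. Compound 3 `COc1ccc(C(=O)/C=C/c2ccc(OCc3cn(-c4ccnc5cc(Cl)ccc45)nn3)c(OC)c2)c(OC)c1` is not yet measured; it differs from compound 2 by 2,4-dimethoxyphenyl in place of methyl on a carbonyl carbon. Within the data shown here, no measured pair shows this single change, so the expected step of a 1.9-fold higher number from compound 2 to compound 3 (0.29 log units; within the scatter) in this assay is small, upward, and not clearly beyond the scatter. Compound 3 is therefore estimated at 0.2 h, expected between 0.07 h and 0.6 h.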

Compound 3, half-life in the liver assay: 0.947 h
Compound 3: middle estimate off by 4.7-fold (0.68 log units), on the low side; the whole stated range lies below it.
By their numbers in the liver assay, from the lowest: compound 2; then compounds 1 and 3 (each within the scatter of the next).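

In the liver assay, 2,4-dimethoxyphenyl in place of methyl on a carbonyl carbon gives a 9.2-fold higher number from compound 2 to compound 3 (0.96 log units; beyond the scatter), the first step read at this position, and it shows that the number responds to the group placed there. The larger group also comes with a change in a physicochemical assay for lipophilicity, read by HPLC, at pH 7.4; a higher number here means a more lipophilic compound, a lower number a more polar compound: the measured distribution coefficient of compound 2, 3.6, and of compound 3, 4.3, a number 0.70 log units higher (beyond the scatter) In the physicochemical assay compound 2 gives 3.6 and compound 3 gives 4.3.

This single pair cannot separate the contribution of the aromatic ring from that of its two methoxy groups, or tie the change in the liver assay to the change in the physicochemical assay. As far as these compounds go, how an unsubstituted phenyl or a morpholine-bearing chain would behave on this carbonyl carbon remains open.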